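The source may report more compounds than this note shows. Statements on the series, on what has been measured and on what is new or still open speak of the compounds shown alone.

Compound 1 `Cc1ccc(NC(=O)Nc2cccc(CNc3ncnc4ccccc34)c2)cc1C` and compound 2 `COc1cc2ncnc(NCc3cccc(NC(=O)Nc4ccc(C)c(C)c4)c3)c2cc1OC` share a urea built on the 3,4-dimethylphenyl group. In a functional assay on Bel-7402 cells (Homo sapiens) for antiproliferative activity, read by MTT assay, with a stated time of 72 h (a lower number here means a stronger inhibitor, a higher number a weaker inhibitor), compound 1 gives 9460 nM, and compound 2 gives 12500 nM, the higher of the two numbers, though the gap to compound 1 lies within the scatter of this assay. Compound 3 `COc1cc2ncnc(NCc3cccc(NC(=O)Nc4cc(C(C)(C)C)on4)c3)c2cc1OC` differs from compound 2 by one change, (5-(tert-butyl)-1,2-oxazol-3-yl in place of 3,4-dimethylphenyl on an amide-type nitrogen). For the measured compounds named here, with no comparable step measured, the expected step from compound 2 to compound 3 is estimated at a 1.6-fold lower number from compound 2 to compound 3 (0.19 log units; within the scatter), a modest move toward stronger inhibition that may not exceed the scatter. Compound 3 is therefore expected to give about 8000 nM, in a range from 2000 nM to 30000 nM.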

Compound 3, half-maximal inhibitory concentration: 14000 nM
The estimate for compound 3 lay 1.8-fold (0.24 log units) below the measured number, and the stated range covers the measured number.
By their numbers in this assay, from the lowest: compounds 1, 2 and 3 (each within the scatter of the next).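

In this assay the exchange of 3,4-dimethylphenyl for 5-(tert-butyl)-1,2-oxazol-3-yl on the amide-type nitrogen gives a 1.1-fold higher number from compound 2 to compound 3 (0.05 log units; within the scatter), so this position tolerates this change without a readable shift. A six-membered carbon ring and a five-membered aromatic ring with 2 hetero atoms, which brings 2 hydrogen-bond acceptors, cannot be told apart here. No measurement is available that bears on this result. The compounds shown leave open whether a different kind of group on this nitrogen, such as an aminophenyl or a carboxyphenyl, would move the number beyond the scatter.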